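A few compounds are considered here, and "the series" means these few. Any claim that something is new, unique, unknown or untested is made for them only; others in the source may bear on it.

Working notes on the series.

Compound 1 `O=S(=O)(/C=C/c1ccc(Cl)cc1Cl)Cc1ccc(Nc2ncnc3ccc(Br)cc23)cc1` gives 100 nM in a functional assay on ACHN cells (Homo sapiens); a lower number here means a stronger inhibitor of growth, a higher number a weaker inhibitor of growth. Compound 2 `O=S(=O)(/C=C/c1ccc(C(F)(F)F)cc1F)Cc1ccc(Nc2ncnc3ccc(Br)cc23)cc1` gives 16000 nM in this assay, which means a 160-fold higher number from compound 1 to compound 2 (2.20 log units; beyond the scatter); the change is 2-fluoro-4-(trifluoromethyl)phenyl in place of 2,4-dichlorophenyl on a double-bonded chain carbon bound to a double-bonded chain carbon.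

Compound 3 `O=S(=O)(/C=C/c1ccc(Cl)cc1Cl)Cc1ccc(Nc2ncnc3cc(Cl)ccc23)cc1` carries a different core from compound 1, and the difference between the two cores is not broken down here. In this assay compound 3 gives 8000 nM. Set beside compound 2, the two values lie within the scatter of each other, so nothing is made of their order; set beside compound 1, the number for compound 3 is far higher.

Compound 4 `O=S(=O)(/C=C/c1ccc(C(F)(F)F)cc1F)Cc1ccc(Nc2ncnc3cc(Cl)ccc23)cc1` is not yet measured. It stands to compound 3 as compound 2 stands to compound 1: the change is 2-fluoro-4-(trifluoromethyl)phenyl in place of 2,4-dichlorophenyl on a double-bonded chain carbon bound to a double-bonded chain carbon, the same change as before, at the same place. The earlier step was large. Whether the same size of step repeats on the core of compound 3 is uncertain, since compound 3 already sits at a high number and the assay may not resolve a much higher one, in which case only a limit would be reported.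

For compound 4 the expected step in this assay is a 10-fold higher number from compound 3 to compound 4 (1.00 log units; beyond the scatter), resting on the earlier change because a 160-fold higher number from compound 1 to compound 2 (2.20 log units; beyond the scatter) was observed. Compound 4 is therefore estimated at 80000 nM, with the expected range from 10000 nM to 1000000 nM.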

Compound 4, concentration for 50% growth inhibition: > 100000 nM
Compound 4: a limit, no number; the forecaster's own chance of this, stated with the estimate: 55%; at least 1.2-fold (0.09 log units) between middle value and limit.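

In this assay compound 4 gives > 100000 nM, which is a limit of the assay and not a number. Even so, the change to 2-fluoro-4-(trifluoromethyl)phenyl in place of 2,4-dichlorophenyl goes the same way on the second core as on the first, for there is an at least 12-fold higher number from compound 3 to compound 4 (1.09 log units; beyond the scatter), and with that group held fixed, the difference between the two cores also comes with an at least 6.2-fold higher number from compound 2 to compound 4 (0.79 log units; beyond the scatter). This shows that the direction of the change carries over on these two cores, but it does not show whether the size of the step carries over as well: the same change on two cores in this assay, a 160-fold higher number (2.20 log units; beyond the scatter) from compound 1 to compound 2 and an at least 12-fold higher number (1.09 log units; beyond the scatter) from compound 3 to compound 4; the limit leaves it open whether they differ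

From the compounds shown here alone, how large the step on the core of compound 3 really is stays open, and a measured number for compound 4 would be needed to settle it: the limit of > 100000 nM in this assay, at which 1 of the 4 values shown sits. Also open is how the same change behaves on any core other than these two, and how an unsubstituted phenyl or a methoxyphenyl would read on the same chain carbon, as the direction rests on two pairs of compounds and two aryl groups only.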